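Replacing the acid with an alcohol on the shared core

The source may report more compounds than this note shows. Statements on the series, on what has been measured and on what is new or still open speak of the compounds shown alone.

Compound 3 `CN1CC[C@H](c2ccc(Cl)cc2)[C@@H](CCC(=O)O)C1` gives 425 nM in an assay on Cortex with Norepinephrine transporter (Rattus norvegicus) as the target (a lower number here means a stronger inhibitor, a higher number a weaker inhibitor), the highest of the three numbers recorded. Compound 1 `CN1CC[C@H](c2ccc(Cl)cc2)[C@@H](C(=O)OC(C)(C)C)C1` gives 350 nM, and compound 2 `C=CCOC[C@H]1CN(C)CC[C@@H]1c1ccc(Cl)cc1` gives 20 nM. The change to compound 4 `CN1CC[C@H](c2ccc(Cl)cc2)[C@@H](CCCO)C1` is hydroxymethyl in place of carboxy on a saturated chain carbon, two bonds along the chain from a saturated ring carbon. Within the data shown here, two steps bear on it: an 18-fold lower number from compound 1 to compound 2 (1.24 log units; beyond the scatter) and a 21-fold higher number from compound 2 to compound 3 (1.33 log units; beyond the scatter), both showing that a neutral side chain on this ring carbon sits far below the ester or the acid, whereas a 1.2-fold higher number from compound 1 to compound 3 (0.08 log units; within the scatter) shows the ester and the acid side by side. Removing the acid while keeping an oxygen is therefore expected to bring a lower number in this assay, though perhaps not the whole way to compound 2. Compound 4 is expected near 80 nM, between 25 nM and 300 nM, a step estimated as a 5.3-fold lower number from compound 3 to compound 4 (0.73 log units; beyond the scatter).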

Compound 4, inhibition constant: 564 nM
Compound 4: the middle estimate sits 7.1-fold (0.85 log units) below what was measured, and the stated range ends below it.
By their numbers in this assay, from the lowest: compound 2; then compounds 1, 3 and 4 (each within the scatter of the next).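

In this assay, hydroxymethyl in place of carboxy leaves the reading within the scatter (a 1.3-fold higher number from compound 3 to compound 4 (0.12 log units; within the scatter)), and 3-hydroxypropyl reads alike with tert-butoxycarbonyl (a 1.6-fold higher number from compound 1 to compound 4 (0.21 log units; within the scatter)). Losing the carboxy therefore does not by itself carry a side chain to the level of compound 2, which stays well apart from compound 4 (a 28-fold higher number from compound 2 to compound 4 (1.45 log units; beyond the scatter)). No measurement at hand explains this gap. Still open, going by these compounds, is whether an ether on the 3-hydroxypropyl chain, or an amine in place of its hydroxyl, would shift the number.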